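Trifluoromethyl Gives Way to Fluoro in a Weak Series

The source may hold more compounds than are shown below. What is called first, only, known or untested is meant among the compounds shown, and "the series" means these compounds.

Of the compounds shown here, three that share one core have been tested in an assay on CHO cells for displacement of a labelled ligand from adenosine receptor A3 (Homo sapiens), read by scintillation counting, with a stated time of 3 h; on this read-out higher numbers stand for weaker inhibition and lower numbers for stronger inhibition. Compound 1 `Cc1ccc(C(=O)Nc2nc(Cl)c3cn(C)nc3n2)cc1` gives 13500 nM, compound 2 `Cn1cc2c(Cl)nc(NC(=O)c3ccccc3)nc2n1` gives 23600 nM, and compound 3 `Cn1cc2c(Cl)nc(NC(=O)c3ccc(C(F)(F)F)cc3)nc2n1` gives 33500 nM. Compound 3 thus shows the highest of the three numbers; its nearest neighbour is compound 2 and its furthest is compound 1. The steps among these three are small: a 1.7-fold higher number from compound 1 to compound 2 (0.24 log units; within the scatter) for hydrogen in place of methyl on an aromatic carbon, a 2.5-fold higher number from compound 1 to compound 3 (0.39 log units; beyond the scatter) for trifluoromethyl in place of methyl, and a 1.4-fold higher number from compound 2 to compound 3 (0.15 log units; within the scatter) for trifluoromethyl in place of hydrogen.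

Compound 4 `Cn1cc2c(Cl)nc(NC(=O)c3ccc(F)cc3)nc2n1` has not yet been measured in this assay. It differs from compound 3 by fluoro in place of trifluoromethyl on an aromatic carbon. Among the measured compounds shown here, the steps that bear on this change are the two that brought trifluoromethyl in, the one starting from methyl and the one starting from hydrogen, both modest. For the measured compounds named here, since the only measured step from hydrogen to trifluoromethyl on that carbon is a 1.4-fold higher number from compound 2 to compound 3 (0.15 log units; within the scatter), a single fluorine in that place is expected to sit near the level of compound 2, giving an expected step of a 1.5-fold lower number from compound 3 to compound 4 (0.18 log units; within the scatter) in this assay, downward but within the scatter. Compound 4 is therefore estimated at 22000 nM, with a range from 10000 nM to 50000 nM.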

Compound 4, inhibition constant: 31900 nM
The estimate for compound 4 lay 1.5-fold (0.16 log units) below the measured number; the range from low to high includes it.
By their numbers in this assay, from the lowest: compounds 1, 2, 4 and 3 (each within the scatter of the next, the first and the last beyond it).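

In this assay fluoro in place of trifluoromethyl, on an aromatic carbon para to a large group, gives a 1.1-fold lower number from compound 3 to compound 4 (0.02 log units; within the scatter) even though the group falls from 4 heavy atoms to 1. Fluoro in place of hydrogen gives a 1.4-fold higher number from compound 2 to compound 4 (0.13 log units; within the scatter) as well, so hydrogen, fluoro and trifluoromethyl now form a set of three that this read-out does not separate, where the earlier compounds held only two of them. Methyl alone stands modestly apart, with a 2.4-fold higher number from compound 1 to compound 4 (0.37 log units; beyond the scatter) matching a 2.5-fold higher number from compound 1 to compound 3 (0.39 log units; beyond the scatter) in direction and size, yet compound 2 goes against a clean split, for hydrogen gives only a 1.7-fold higher number from compound 1 to compound 2 (0.24 log units; within the scatter) and stays within the scatter.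

The compounds shown leave open whether an amine, a carboxylic acid or a longer chain such as ethyl on this carbon would move the number out of this narrow band, and whether any group here could bring the series far below the level of compound 1. Nothing at hand explains why these groups read so much alike.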